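Amide to urea at the shared core and the expected effect

The compounds below may be only part of what the source reports. "The series", "measured", "known", "first", "only" and "open" are said of these compounds alone.

This account follows a single change made to compound 1 `COc1cc(Cl)cc(-c2nn(-c3cccc(NC(=O)c4ccc(Cl)c(Cl)c4)c3)cc2-c2ccncc2)c1` and what it is expected to do. In a functional assay on SF-295 cells (Homo sapiens) for inhibition, read by sulforhodamine B assay, with a stated time of 48 h, tested at 10 uM (on this read-out higher numbers stand for a weaker effect at the one concentration tested and lower numbers for a stronger effect), compound 1 gives 36.1%, the highest of the three numbers in hand. Two ureas sit far below it: compound 2 `COc1cc(Cl)cc(-c2nn(-c3cccc(NC(=O)Nc4ccc(Cl)c(C(F)(F)F)c4)c3)cc2-c2ccncc2)c1` gives -7.48% and compound 3 `COc1cc(Cl)cc(-c2nn(-c3cccc(NC(=O)Nc4ccc(Cl)c(Cl)c4)c3)cc2-c2ccncc2)c1` gives -2.42%. The step of a number 43.6 percentage points lower from compound 1 to compound 2 (beyond the scatter) and the step of a number 38.5 percentage points lower from compound 1 to compound 3 (beyond the scatter) both show that exchanging the aryl group on the carbonyl carbon for an arylamino group lowers the read-out sharply, while the step of a number 5.1 percentage points higher from compound 2 to compound 3 (within the scatter) shows that the substituent pattern on that aryl ring matters little between the two ureas.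

Compound 4 `COc1cc(Cl)cc(-c2nn(-c3cccc(NC(=O)Nc4cccc(C(F)(F)F)c4)c3)cc2-c2ccncc2)c1` differs from compound 1 in the same manner: (3-(trifluoromethyl)phenyl)amino in place of 3,4-dichlorophenyl on a carbonyl carbon. Since the two measured amide-to-urea steps were large and in the same direction, a large drop is expected here as well, with compound 4 estimated at 0%, between -15% and 20%, a step of a number 36.1 percentage points lower from compound 1 to compound 4 (beyond the scatter).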

Compound 4, a percentage reported as activity, at one concentration (the size of the read-out at that concentration, not a potency): -7.87%
Compound 4: the middle estimate sits 7.9 percentage points above what was measured; the range from low to high includes it.
By their numbers in this assay, from the lowest: compounds 4, 2 and 3 (each within the scatter of the next); then compound 1.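

The step of a number 44 percentage points lower from compound 1 to compound 4 (beyond the scatter) in this assay is a third large amide-to-urea change, and here the urea ring carries no chloro, so among these ureas the drop does not depend on that substituent. The step of a number 0.4 percentage points lower from compound 2 to compound 4 (within the scatter), with hydrogen in place of chloro, and the step of a number 5.5 percentage points lower from compound 3 to compound 4 (within the scatter), with 3-(trifluoromethyl)phenyl in place of 3,4-dichlorophenyl, both lie within the scatter, so these ring changes do not separate the three ureas at this concentration. Nothing measured here explains the effect of the urea.

A single concentration leaves open whether the ureas differ in potency. Also open, as far as these compounds go, is whether the drop needs an aromatic ring on the urea nitrogen, or would also appear with a cyclohexylamino or methylamino group on the carbonyl carbon.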